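This account rests on a few compounds, and the source may have more. Where it says the series, first, only, none or still open, it means among the compounds named here.

Measured so far in a functional assay on HeLa cells (Homo sapiens) for inhibition, with a stated time of 72 h; a higher number here means that more compound is needed for the effect, a lower number that less compound is needed:
- compound 1 `COc1cc(CNC2CCCCC2)ccc1OCc1ccc(Cl)nc1` gives "nd(insoluble)" (no result reported)
- compound 2 `COc1cc(OCc2cnc(Cl)c(Cl)c2)ccc1CNCc1ccncc1` gives 400 nM
- compound 3 `COc1cc(CNCc2ccncc2)ccc1OCc1ccc(F)cc1` gives 6400 nM

Compound 1 offers no number for comparison. Of the two numbers, that of compound 3 (6400 nM) is the higher, and its gap to compound 2 lies beyond the scatter.

The next analogue is compound 4 `COc1cc(CNCc2ccncc2)ccc1OCc1ccc(Cl)cc1`, which differs from compound 3 in one place: chloro in place of fluoro on an aromatic carbon, para to a large group (chloro in place of fluoro on an aromatic carbon), so that 4-fluorobenzyl becomes 4-chlorobenzyl. Among the measured compounds shown here, no measured pair shows a change of this kind, which leaves the size of the step poorly constrained. For the measured compounds named here, the only anchor is compound 2 (400 nM), which shows that numbers well under that of compound 3 occur. A modest move toward a lower number in this assay is expected, close to the edge of the scatter. The estimated step is a 2.6-fold lower number from compound 3 to compound 4 (0.41 log units; beyond the scatter), and a result within the scatter would not be surprising. The expected value for compound 4 is 2500 nM, with an estimated range of 700 nM to 7000 nM.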

Compound 4, half-maximal effective concentration: 890 nM
Estimate against measurement, compound 4: 2.8-fold (0.45 log units) above; the measured number falls inside the stated range.
By their numbers in this assay, from the lowest: compound 2; then compound 4; then compound 3.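

In this assay, chloro in place of fluoro on an aromatic carbon, para to a large group, gives a 7.2-fold lower number from compound 3 to compound 4 (0.86 log units; beyond the scatter). Among the compounds shown here, this is the first step that can be read at a single place, and it shows that the number responds to the identity of the halogen at this position. Only one heavy atom is exchanged, with no ring, hydrogen-bond donor, hydrogen-bond acceptor or net charge entering or leaving, and no measurement at hand gives a cause for the step.

As far as these compounds go, whether bromo, methyl, methoxy or trifluoromethyl at this carbon would extend the step or reverse it remains open. The reading rests on a single pair, so it is also unsettled whether the same exchange would move the number similarly with a different amine, such as cyclohexylamine, on the core.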